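This account rests on a few compounds, and the source may have more. Where it says the series, first, only, none or still open, it means among the compounds named here.

Compound 1 `CN(C)CCNc1nc(N/N=C/c2ccc(F)cc2Cl)nc2ccccc12`: 680 nM
Compound 2 `CN(C)CCNc1nc(N/N=C/c2nccn2Cc2ccccc2)nc2ccccc12`: 9600 nM

In a functional assay on HepG2 cells (Homo sapiens) for cytotoxicity, read by MTT assay, with a stated time of 72 h (on this read-out lower numbers stand for stronger inhibition and higher numbers for weaker inhibition), compound 2 gives the highest of the two numbers, and compound 1 gives a number lower than that of compound 2 by an amount beyond the usual scatter. Compound 3 `Cc1ccc(Cn2ccnc2/C=N/Nc2nc(NCCN(C)C)c3ccccc3n2)cc1` differs from compound 2 by a single change: methyl in place of hydrogen on an aromatic carbon. Within the data shown here, no pair of measured compounds shows this kind of change, so nothing directly comparable is available. A step in this assay that stays within the scatter, with no clear direction, is expected here. Compound 3 is therefore estimated at 8000 nM, with a range from 3000 nM to 25000 nM. That estimate corresponds to an expected step of a 1.2-fold lower number from compound 2 to compound 3 (0.08 log units; within the scatter).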

Compound 3, half-maximal inhibitory concentration: 2980 nM
Compound 3: the middle estimate sits 2.7-fold (0.43 log units) above what was measured, and the stated range ends above it.
By their numbers in this assay, from the lowest: compound 1; then compound 3; then compound 2.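

In this assay, going from benzyl to 4-methylbenzyl gives a 3.2-fold lower number from compound 2 to compound 3 (0.51 log units; beyond the scatter). Among these compounds, this shows that the number responds to a single added carbon on this six-membered aromatic ring, at the place para to a large group, which the earlier compounds could not show. Nothing measured here explains why the number falls.

As far as these compounds go, it remains open whether an ethyl, a methoxy or an amine at this same place would lower the number further or raise it. From the compounds shown here alone, it is also open whether a methyl elsewhere on this ring would produce a similar step.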